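The source may report more compounds than this note shows. Statements on the series, on what has been measured and on what is new or still open speak of the compounds shown alone.

Measured compounds:
- compound 1 `CCCCCCN(Cc1nnn[nH]1)c1ccccc1`: 4.78
- compound 2 `Cc1ccc(N(Cc2nnn[nH]2)Cc2ccc(F)cc2F)cc1`: 4.23
- compound 3 `Cc1ccc(N(Cc2nnn[nH]2)Cc2ccc(Cl)cc2Cl)cc1`: 4.26

In a physicochemical assay for acid dissociation, compound 1 gives the highest of the three numbers. Compound 3 comes nearest to it, with a number beyond the scatter lower, and compound 2 lies furthest, also beyond the scatter lower. Compounds 2 and 3 are within the scatter of each other, so nothing separates them. Within the data shown here, both carry a substituted benzyl group on the nitrogen and a methyl on the aromatic ring, so neither differs from compound 1 in a single place, and no step between measured compounds is available.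

The unmeasured compound 4 `Clc1ccc(CN(Cc2nnn[nH]2)c2ccccc2)cc1` departs from compound 1 by 4-chlorophenyl in place of pentyl on a saturated chain carbon bound to a nitrogen on an aromatic ring. This brings compound 4 closer to the pattern of compounds 2 and 3, which both read lower than compound 1 in this assay, but compound 4 keeps the unsubstituted phenyl of compound 1, so the comparison is not exact.

A downward step, beyond the scatter, is expected from compound 1 to compound 4, about a number 0.43 log units lower from compound 1 to compound 4 (beyond the scatter) in this assay. Compound 4 is estimated at 4.35, within a range from 4.05 to 4.65.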

Compound 4, acid dissociation constant: 4.38
Beside the measured number, compound 4's estimate is 0.03 log units below it, and the stated range covers the measured number.
By their numbers in this assay, from the lowest: compounds 2, 3 and 4 (each within the scatter of the next); then compound 1.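

The series now has its first comparison at a single place: on a saturated chain carbon bound to a nitrogen on an aromatic ring, 4-chlorophenyl in place of pentyl gives a number 0.40 log units lower from compound 1 to compound 4 (beyond the scatter) in this assay. Among these compounds, the read-out therefore responds to the group at this position while the shared core and the unsubstituted phenyl stay as they are, a finding that the earlier compounds, which differ from each other and from compound 1 in more than one place, could not isolate. No measurement at hand gives a reason for this step, and this single exchange cannot divide it among the loss of the pentyl chain, the entry of the aromatic ring and the entry of the chlorine.

Open, from the compounds shown here alone, is whether the step belongs to the ring or to the chlorine, a question that a plain phenyl or a 4-methoxyphenyl at this place would address. Also open, going by these compounds, is how the number in this assay would move with a longer chain, or with a chain ending in an amine or a carboxylic acid.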